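Aryl versus alkyl ester on the dichlorophenyl cyclopentene core

A few compounds are considered here, and "the series" means these few. Any claim that something is new, unique, unknown or untested is made for them only; others in the source may bear on it.

Among the compounds with values here, compound 2 `CC(C)OC(=O)C1=C(c2ccc(Cl)c(Cl)c2)CCC1` carries the lowest of the two numbers so far in an assay on COS-1 cells for displacement of a labelled ligand from sodium-dependent dopamine transporter (Homo sapiens) (on this read-out lower numbers stand for stronger inhibition and higher numbers for weaker inhibition), giving 2600 nM in this assay. Within the data shown here, its only measured neighbour is compound 1 `CCN(CC)C(=O)C1=C(c2ccc(Cl)c(Cl)c2)CCC1`, which in this assay gives 94000 nM; the step of a 36-fold lower number from compound 1 to compound 2 (1.56 log units; beyond the scatter) came with isopropoxy in place of diethylamino on the carbonyl carbon. Compound 3 `Cc1cccc(OC(=O)C2=C(c3ccc(Cl)c(Cl)c3)CCC2)c1` changes the ester side instead: 3-methylphenyl in place of isopropyl on an oxygen next to a carbonyl group. Among the measured compounds shown here, no measured step exchanges one group for another on that oxygen, so the step from compound 1 to compound 2 bears on it only in showing that the carbonyl substituent matters for this assay; it does not tell the direction of an alkyl-to-aryl exchange. The expectation for compound 3 is therefore a step of a 1.3-fold lower number from compound 2 to compound 3 (0.11 log units; within the scatter) of modest size, with either direction possible. Compound 3 is estimated at 2000 nM in this assay, with a range from 400 nM to 10000 nM.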

Compound 3, inhibition constant: 60 nM
Beside the measured number, compound 3's estimate is 33-fold (1.52 log units) above it; measured number below the stated range.
By their numbers in this assay, from the lowest: compound 3; then compound 2; then compound 1.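

On an oxygen next to a carbonyl group, the exchange of isopropyl for 3-methylphenyl gives a 43-fold lower number from compound 2 to compound 3 (1.64 log units; beyond the scatter) in this assay, so the group on this oxygen matters strongly for this read-out and not only the choice between amide and ester. Together with a 36-fold lower number from compound 1 to compound 2 (1.56 log units; beyond the scatter), this gives two large steps in the same direction across the three compounds, with compound 3 holding the lowest number, and no compound goes against that order. Nothing measured on these compounds accounts for the size of the new step. With 3-methylphenyl as the only ring on this oxygen, the compounds shown do not separate the contribution of the ring from that of its methyl group. Unsubstituted phenyl on the same oxygen would separate the two, while a benzyl group or a longer alkyl chain would test whether an aromatic ring is needed at all.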